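Swapping cyclobutyl for isopropyl on the ring amine side chain

A few compounds are considered here, and "the series" means these few. Any claim that something is new, unique, unknown or untested is made for them only; others in the source may bear on it.

Measured so far:
compound 1, `CCN1CCc2c(sc(NC=O)c2C(N)=O)C1`, > 25000 nM;
compound 2, `NC(=O)c1c(NC(=O)Nc2ccc(Cl)cc2)sc2c1CCN(CC1CCC1)C2`, 1360 nM;
compound 3, `CC[N+]1(CC2CC2)CCc2c(sc(NC(=O)Nc3ccc(Cl)cc3)c2C(N)=O)C1`, 100 nM.

In a functional assay (strain AB) with Danio rerio as the target, read by microscopy, with a stated time of 1 h (a lower number here means that less compound is needed, a higher number that more compound is needed for the effect), compound 1 reaches only the limit of the limit of > 25000 nM in this assay, at which 1 of the 3 values shown sits, so no number is known for it. Among the two numbers, compound 2 has the higher one, and compound 3 sits at a lower value. Compound 4, `CC(C)CN1CCc2c(sc(NC(=O)Nc3ccc(Cl)cc3)c2C(N)=O)C1`, is not yet measured; it differs from compound 2 by isopropyl in place of cyclobutyl on a saturated chain carbon bound to an amine nitrogen in a ring. Among the compounds with values here, no measured pair shows this exact change, so a step from compound 2 to compound 4 of little size is expected, likely within the usual scatter. The value of compound 4 is estimated at 1800 nM, between 600 nM and 5500 nM, as the step of a 1.3-fold higher number from compound 2 to compound 4 (0.12 log units; within the scatter) is expected to be small.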

Compound 4, half-maximal effective concentration: 4510 nM
Estimate against measurement, compound 4: 2.5-fold (0.40 log units) below; the measured number falls inside the stated range.
By their numbers in this assay, from the lowest: compound 3; then compound 2; then compound 4. At a limit, above all of these: compound 1.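

In this assay the side chain on the ring amine is not a silent place: isopropyl in place of cyclobutyl gives a 3.3-fold higher number from compound 2 to compound 4 (0.52 log units; beyond the scatter) and so does not stand in equally for the carbon ring. Within the data shown here, this is the first single change read at this position, and it shows that the group there affects the number. Nothing measured here accounts for the size of this step.

This one change removes the ring and a carbon together, and the two effects cannot be told apart here. From the compounds shown here alone, how a straight butyl chain or a cyclopentyl group on this carbon would read remains open.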